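The source may report more compounds than this note shows. Statements on the series, on what has been measured and on what is new or still open speak of the compounds shown alone.

In an assay on isolated protein for binding affinity to 5-hydroxytryptamine receptor 6 (Homo sapiens) (a higher number here means a weaker inhibitor, a lower number a stronger inhibitor), three compounds have been measured so far:

compound 1 `COc1ccc(S(=O)(=O)Nc2ccc(Cl)c(Cl)c2)cc1N1CCNCC1` gives 2.51 nM
compound 2 `COc1cc(Cl)c(C)cc1NS(=O)(=O)c1ccc(OC)c(N2CCNCC2)c1` gives 2 nM
compound 3 `COc1ccc(S(=O)(=O)Nc2cc(Br)cc(Cl)c2Cl)cc1N1CCNCC1` gives 3.98 nM

Compound 1 stands second highest of these three numbers, but all three lie close together: the gap to compound 2 and the gap to compound 3 are both within the usual scatter of repeated measurements, so none of the three can be called stronger or weaker than another.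

The next compound, compound 4 `COc1ccc(S(=O)(=O)Nc2cc(Br)cc(Br)c2F)cc1N1CCNCC1`, differs from compound 1 at one place only: 3,5-dibromo-2-fluorophenyl in place of 3,4-dichlorophenyl on a sulfonamide nitrogen. The halogenated ring on the sulfonamide nitrogen is thus exchanged for another halogenated ring of similar make-up.

Within the data shown here, only one measured step bears on this kind of change, the one from compound 1 to compound 3, where the same ring was swapped for a different halogen pattern: a 1.6-fold higher number from compound 1 to compound 3 (0.20 log units; within the scatter). That step stayed within the scatter, which suggests that altering the halogen pattern on this ring does not move the number much. The expectation for compound 4 is therefore a step of about a 1.4-fold higher number from compound 1 to compound 4 (0.14 log units; within the scatter), not beyond the scatter. On that basis compound 4 is estimated at 3.5 nM, with a range from 1.5 nM to 8 nM.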

Compound 4, inhibition constant: 2.51 nM
Beside the measured number, compound 4's estimate is 1.4-fold (0.14 log units) above it, within the range that was stated.
By their numbers in this assay, from the lowest: compounds 2, 1, 4 and 3 (each within the scatter of the next).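

In this assay, putting 3,5-dibromo-2-fluorophenyl on the sulfonamide nitrogen gives a result close to both earlier rings on the shared core: no change at the digits printed from compound 1 to compound 4 (within the scatter) and a 1.6-fold lower number from compound 3 to compound 4 (0.20 log units; within the scatter). This position has now held three halogen patterns, one with chlorine alone, one with bromine and chlorine, and one with bromine and fluorine, and compounds 1, 3 and 4 all remain within the scatter of one another, so fluorine can enter this ring and chlorine can leave it entirely without a step beyond the scatter in these compounds. No supporting measurement is available to explain this result.

Going by these compounds, all three of these rings are halogenated phenyl groups, so it remains open whether the same tolerance would hold for an unsubstituted phenyl ring or for a phenyl ring carrying a nitrile or a carboxylic acid. Among these compounds, it is also open how far the 3,5-dibromo-2-fluorophenyl result depends on each of its three halogens, since no compound here carries only one or two of them in the same places.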